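Butyl-to-hydrogen truncation on the chalcogen chain: compound 4

The compounds below may be only part of what the source reports. "The series", "measured", "known", "first", "only" and "open" are said of these compounds alone.

Compound 1 `CCCCCSc1nc(NCc2ccc([Se]C)cc2)c2ccccc2n1` and compound 2 `CSc1nc(NCc2ccc([Se]C)cc2)c2ccccc2n1` share one core; compound 3 `CCCCC[Se]c1nc(N)c2cccnc2n1` and compound 4 `C[Se]c1nc(N)c2cccnc2n1` share another, and the difference between the two cores is not broken down here. In a functional assay on MCF7 cells (Homo sapiens) for cytotoxicity, read by MTT assay, with a stated time of 72 h (a lower number here means that less compound is tolerated, a higher number that more compound is tolerated), compound 1 reaches only a limit of the assay, > 100000 nM. In this assay compound 2 likewise reaches only a limit, > 100000 nM. The change between them, (hydrogen in place of butyl on a saturated chain carbon bound to a sulfur), therefore gives a step that the two limits leave unreadable from compound 1 to compound 2, because both values sit at the limit of > 100000 nM in this assay, at which 2 of the 3 values shown sit. In this assay, among the measured compounds shown here, compound 3 gives 85000 nM, the only number among the three values. The change to compound 4, (hydrogen in place of butyl on a saturated chain carbon bound to a selenium atom), is the same kind of change as that from compound 1 to compound 2, not the same: one place is bound to a sulfur, the other to a selenium atom. With the earlier step unreadable, the expected size rests on compound 3 alone, and a step of a 1.3-fold higher number from compound 3 to compound 4 (0.11 log units; within the scatter) is expected. Compound 4 is expected near 110000 nM, between 40000 nM and 300000 nM, with a real chance that this assay again reports only a limit.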

Compound 4, concentration lethal to 50% of the cells: > 100000 nM
Compound 4: a limit, no number (the forecaster's own chance of this, stated with the estimate: 55%); the middle value lies beyond the limit too.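

In this assay, the change from butyl to hydrogen on the saturated chain carbon bound to a selenium atom gives an at least 1.1-fold higher number from compound 3 to compound 4 (0.07 log units; that floor lies within the scatter); compound 4 is a limit, so this step is a floor and not a size. Among the compounds shown here, the same kind of change on the chain carbon bound to a sulfur, in the core of compound 1, cannot be read, so there is no second step to set against the first, and carrying the change from one core to the other is neither supported nor contradicted. The comparison stays untested because the values gather at a single limit: the limit of > 100000 nM in this assay, at which 3 of the 4 values shown sit.

Open, on these data alone, is how a longer chain, such as octyl, or a chain ending in an amine or a carboxylic acid, would read on either core in this assay. Also open, as far as these compounds go, is whether exchanging sulfur and selenium at this place on a single core changes the result.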